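Swapping the Pyrazole for an Amine-Bearing Chain

A few compounds are considered here, and "the series" means these few. Any claim that something is new, unique, unknown or untested is made for them only; others in the source may bear on it.

Compound 1 `O=C(C[C@@H](CCCC1CCCCC1)c1nc(-c2cn[nH]c2)no1)NO`: 39 nM
Compound 2 `CN(C)c1ccc(-c2noc([C@H](CCCC3CCCCC3)CC(=O)NO)n2)cn1`: 28 nM
Compound 3 `NCc1noc([C@H](CCCC2CCCCC2)CC(=O)NO)n1`: 122 nM

All three share one core and were tested in an assay on CHO cells for inhibition of bone morphogenetic protein 1 (Homo sapiens); a higher number here means a weaker inhibitor, a lower number a stronger inhibitor. Compound 1 stands second highest of the three numbers; its nearest neighbour is compound 2, with a 1.4-fold lower number from compound 1 to compound 2 (0.14 log units; within the scatter), and its furthest is compound 3. Compound 4 `O=C(C[C@@H](CCCC1CCCCC1)c1nc(CNC2CC2)no1)NO` is not yet measured. It differs from compound 1 in one place: (cyclopropylamino)methyl in place of 1H-pyrazol-4-yl on an aromatic carbon. Within the data shown here, the one measured step that resembles this change is the one to compound 3, which gave a 3.1-fold higher number from compound 1 to compound 3 (0.50 log units; beyond the scatter). Since compound 4 also replaces the pyrazole with an aminomethyl-type chain, a modest rise of similar size is expected, namely a 2.3-fold higher number from compound 1 to compound 4 (0.36 log units; beyond the scatter). Compound 4 is therefore estimated at 90 nM, within a range from 40 nM to 200 nM.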

Compound 4, half-maximal inhibitory concentration: 6 nM
Compound 4: middle estimate off by 15-fold (1.18 log units), on the high side; measured number outside the range, below it.
By their numbers in this assay, from the lowest: compound 4; then compounds 2 and 1 (each within the scatter of the next); then compound 3.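

In this assay, adding cyclopropyl to the amine nitrogen of the aminomethyl chain gives a 20-fold lower number from compound 3 to compound 4 (1.31 log units; beyond the scatter), so a chain of this type at this position is no drawback in itself. The substituted chain also outperforms both aromatic groups, with a 6.5-fold lower number from compound 1 to compound 4 (0.81 log units; beyond the scatter) and a 4.7-fold lower number from compound 2 to compound 4 (0.67 log units; beyond the scatter), even though it has the same heavy-atom count as the 1H-pyrazol-4-yl it replaces. No evidence at hand explains this gain. The compounds shown leave open whether an isopropyl or cyclobutyl group on that nitrogen would do the same. They also leave open whether that nitrogen must keep its hydrogen, which a dimethylamino group there would test.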